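The source may report more compounds than this note shows. Statements on the series, on what has been measured and on what is new or still open speak of the compounds shown alone.

The measured compounds in a physicochemical assay for lipophilicity, read by HPLC, at pH 7.5; on this read-out higher numbers stand for higher lipophilicity and lower numbers for lower lipophilicity:

Compound 1 `CCOc1ccccc1-c1ccc(-c2nc3cnccc3c(NC(COC)C(N)=O)c2C#N)cc1` gives 2.8.
Compound 2 `CC[C@@H](Nc1c(C#N)c(-c2ccc(-c3cccc(OC)c3)cc2)nc2cnccc12)C(N)=O` gives 2.7.
Compound 3 `CC(C)(CC(N)=O)c1c(C#N)c(-c2ccc(Br)cc2)nc2cnccc12` gives 2.1.

Compound 2 stands second highest of these three numbers in this assay. Compound 1 sits a little higher, but within the scatter, so no order can be read between the two; compound 3 sits lower, by a gap beyond the scatter. Going by the values given here, no two of the measured compounds differ in only one place, so no measured step is available to guide the reading.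

Compound 4 `CC[C@@H](Nc1c(C#N)c(-c2ccc(-c3cccc(CO)c3)cc2)nc2cnccc12)C(N)=O` has not yet been measured in this assay. It differs from compound 2 in one place: hydroxymethyl in place of methoxy on an aromatic carbon. The two groups match in heavy atoms and in acceptors; the hydroxymethyl that enters brings one hydrogen-bond donor where the methoxy that leaves had none.

From this change a downward step in this assay is expected, larger than the scatter, of the size a number 0.70 log units lower from compound 2 to compound 4 (beyond the scatter). Compound 4 is therefore estimated at 2, with a range from 1.5 to 2.5.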

Compound 4, distribution coefficient: 2
Compound 4: the middle estimate sits on the measured number at the digits printed; low and high end bracket the measured number.
By their numbers in this assay, from the lowest: compounds 4 and 3 (each within the scatter of the next); then compounds 2 and 1 (each within the scatter of the next).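

In this assay, hydroxymethyl in place of methoxy on this aromatic carbon gives a number 0.70 log units lower from compound 2 to compound 4 (beyond the scatter). Going by these compounds alone, this is the first step in the set that can be read at a single place, and it shows that the read-out responds at this position of the 3-methoxyphenyl group even when the heavy atoms entering and leaving match in number. The count that differs between the two groups is the one hydrogen-bond donor, but nothing measured here bears on what sets the size of this step.

On these data alone, it remains open how other groups at this place, such as an amine, a carboxylic acid or a longer chain like hydroxyethyl, would read. A single step also cannot say whether the same change would read alike elsewhere on this ring.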